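The source may report more compounds than this note shows. Statements on the series, on what has been measured and on what is new or still open speak of the compounds shown alone.

Values in an ADME assay on BaF3 cells (Mus musculus) for cytotoxicity; a lower number here means that less compound is needed, a higher number that more compound is needed for the effect:
- compound 1 `FC(F)(F)Oc1ccc(Nc2ncnc3c2cnn3C2CCCCC2)cc1`: 9300 nM
- compound 2 `NC(=O)Cn1ncc2c(Nc3ccc(OC(F)(F)F)cc3)ncnc21`: 3300 nM
- compound 3 `FC(F)(F)Oc1ccc(Nc2ncnc3c2cnn3CC2CCOC2)cc1`: a limit of the assay, > 10000 nM

Compound 3 thus sits at the top of the series, at the limit of > 10000 nM in this assay, at which 1 of the 3 values shown sits; no number is known for it. Compound 4 `FC(F)(F)Oc1ccc(Nc2ncnc3c2cnn3Cc2ccccc2)cc1` differs from compound 3 in one place: phenyl in place of oxolan-3-yl on a saturated chain carbon bound to an aromatic nitrogen. Among the compounds with values here, two measured steps touch the same place: an at least 3.0-fold higher number from compound 2 to compound 3 (0.48 log units; beyond the scatter), and an at least 1.0-fold higher number from compound 1 to compound 3 (0.03 log units; that floor lies within the scatter), the latter comparing a ring of carbon only with the oxolane. Compound 1, the closest carbon-only analogue, gives 9300 nM. Compound 4 is therefore expected to stay near the limit, with a step that the limit leaves unreadable from compound 3 to compound 4 not beyond the scatter. The estimate for compound 4 is 12000 nM, within 5000 nM to 30000 nM.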

Compound 4, half-maximal effective concentration: > 10000 nM
Compound 4: only a limit was reported; the forecaster's own chance of this, stated with the estimate: 55%; the middle value is on the limit's open side.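

In this assay, benzyl on the aromatic nitrogen joins (oxolan-3-yl)methyl at the top of the series: the limit of > 10000 nM in this assay, at which 2 of the 4 values shown sit.

Phenyl in place of carbamoyl gives an at least 3.0-fold higher number from compound 2 to compound 4 (0.48 log units; beyond the scatter), so compound 2 remains the only compound shown that is clearly separated from the others, while benzyl in place of cyclohexyl gives an at least 1.0-fold higher number from compound 1 to compound 4 (0.03 log units; that floor lies within the scatter). Compound 3 and compound 4 both carry only a limit of the assay, and the step between them cannot be read.

Open, as far as these compounds go, is whether an amine or a carboxylic acid on this chain carbon would give a number like that of compound 2. Also open, from the compounds shown here alone, is whether a longer chain before the phenyl would bring the value within the readable range.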